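This account rests on a few compounds, and the source may have more. Where it says the series, first, only, none or still open, it means among the compounds named here.

In a functional assay on HCT-116 cells (Homo sapiens) for inhibition, read by MTT assay, with a stated time of 48 h (a higher number here means a weaker inhibitor, a lower number a stronger inhibitor), compound 1 `COc1ccc(CN(C(=O)C(C)C)c2cc(OC)c(OC)c(OC)c2)cc1O` gives 310 nM, while compound 2 `COc1ccc(CN(C(=O)CCCl)c2cc(OC)c(OC)c(OC)c2)cc1O` gives 150 nM. Compound 2 therefore holds the lowest of the two numbers, the step of a 2.1-fold lower number from compound 1 to compound 2 (0.32 log units; beyond the scatter) being a modest move toward a lower number. Compound 3 `COc1ccc(CN(C(=O)CBr)c2cc(OC)c(OC)c(OC)c2)cc1O` differs from compound 2 by bromo in place of chloromethyl on a saturated chain carbon bound to a carbonyl carbon. Among the compounds with values here, only one measured step bears on this place, namely a 2.1-fold lower number from compound 1 to compound 2 (0.32 log units; beyond the scatter), which shows that swapping the group on a carbonyl carbon shifts this assay by a modest amount. Shortening the chain and exchanging the halogen is a change of comparable scale, so a step in this assay no larger than that, and quite possibly within the scatter, is expected, with a slight lean toward a lower number. Compound 3 is accordingly estimated at 120 nM, with a range from 50 nM to 300 nM, corresponding to an expected step of a 1.3-fold lower number from compound 2 to compound 3 (0.10 log units; within the scatter).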

Compound 3, half-maximal inhibitory concentration: 68 nM
Compound 3: the middle estimate sits 1.8-fold (0.25 log units) above what was measured; low and high end bracket the measured number.
By their numbers in this assay, from the lowest: compound 3; then compound 2; then compound 1.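

Bromo in place of chloromethyl on a saturated chain carbon bound to a carbonyl carbon gives a 2.2-fold lower number from compound 2 to compound 3 (0.34 log units; beyond the scatter) in this assay and so shows that this place had not reached its floor at compound 2. Set against isopropyl, bromomethyl on the carbonyl carbon gives a 4.6-fold lower number from compound 1 to compound 3 (0.66 log units; beyond the scatter) and makes compound 3 the strongest of the three, with every step among them beyond the scatter. The step from compound 2 changes chain length and halogen together, so the numbers cannot say which of the two carries it, and nothing available explains the shift.

The compounds shown leave open how a chloromethyl or iodomethyl group on the carbonyl carbon would read, which would separate the halogen from the chain length. Also open, from the compounds shown here alone, is how a longer bromoalkyl chain or an unhalogenated ethyl group would compare.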